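Working notes: chloro in place of methyl

The compounds below may be only part of what the source reports. "The series", "measured", "known", "first", "only" and "open" are said of these compounds alone.

Measured in a functional assay on CHO-TAX 5-6 cells (Cricetulus griseus) for antiproliferative activity, read by sulforhodamine B assay, with a stated time of 48 h; on this read-out higher numbers stand for weaker inhibition and lower numbers for stronger inhibition:
- compound 1 `Cc1cccc(NS(=O)(=O)c2ccc(N3CCNC3=O)cc2)c1`: 150 nM
- compound 2 `CCc1cccc(NS(=O)(=O)c2ccc(N3CCNC3=O)cc2)c1`: 140 nM
- compound 3 `O=C1NCCN1c1ccc(S(=O)(=O)Nc2cccc(Br)c2)cc1`: 76 nM

Compound 1 stands within the scatter of both others, with a 1.1-fold lower number from compound 1 to compound 2 (0.03 log units; within the scatter) and a 2.0-fold lower number from compound 1 to compound 3 (0.30 log units; within the scatter). Compound 4 `O=C1NCCN1c1ccc(S(=O)(=O)Nc2cccc(Cl)c2)cc1` has chloro in place of methyl on an aromatic carbon, meta to a large group (chloro in place of methyl on an aromatic carbon). Going by the values given here, no chloro compound has been measured yet. The second step above, bromo in place of methyl, bears most directly on this change. The step with bromo in place of ethyl, a 1.8-fold lower number from compound 2 to compound 3 (0.27 log units; within the scatter), points the same way. A small step towards a lower number is therefore expected in this assay, not clearly beyond the scatter. The estimated value for compound 4 is 100 nM, with an expected range of 55 nM to 170 nM. The expected change is a 1.5-fold lower number from compound 1 to compound 4 (0.18 log units; within the scatter).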

Compound 4, half-maximal inhibitory concentration: 58 nM
Compound 4: middle estimate off by 1.7-fold (0.24 log units), on the high side; the measured number falls inside the stated range.
By their numbers in this assay, from the lowest: compounds 4, 3, 2 and 1 (each within the scatter of the next, the first and the last beyond it).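

In this assay, going by these compounds alone, chloro on this aromatic carbon gives the first steps that lie beyond the scatter, against methyl (a 2.6-fold lower number from compound 1 to compound 4 (0.41 log units; beyond the scatter)) and against ethyl (a 2.4-fold lower number from compound 2 to compound 4 (0.38 log units; beyond the scatter)). Chloro and bromo are not separated at this position (a 1.3-fold lower number from compound 3 to compound 4 (0.12 log units; within the scatter)). No measurement shown bears on the reason for these steps.

The compounds shown leave open how an amine, a carboxylic acid or a longer chain would read at this position. They also leave open whether the step from 3-methylphenyl to 3-chlorophenyl holds on a changed core.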